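Same Hydrazide Swap on Two Cores, One Readable Result

A few compounds are considered here, and "the series" means these few. Any claim that something is new, unique, unknown or untested is made for them only; others in the source may bear on it.

The series centres on hydrazone derivatives of a flavanone-type scaffold, tested in a functional assay on L5178Y cells (Mus musculus) for inhibition, read by MTT assay, with a stated time of 24 h; a higher number here means a weaker inhibitor, a lower number a stronger inhibitor. Compound 1 `O=C(N/N=C1\C[C@@H](c2ccc(O)cc2)Oc2cc(O)cc(O)c21)c1ccco1` carries a furan-2-yl group on the carbonyl carbon; in this assay compound 1 gives >= 11300 nM, which is a limit of the assay rather than a number. Compound 2 `O=C(Cc1c[nH]c2ccccc12)N/N=C1\C[C@@H](c2ccc(O)cc2)Oc2cc(O)cc(O)c21` is its counterpart with (1H-indol-3-yl)methyl in place of furan-2-yl on a carbonyl carbon, and in this assay compound 2 likewise gives >= 11300 nM, again a limit and not a number. The step from compound 1 to compound 2 is therefore a step that the two limits leave unreadable from compound 1 to compound 2, since both sit at the limit of >= 11300 nM in this assay, at which 2 of the 3 values shown sit.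

Compound 3 `COc1ccc([C@@H]2C/C(=N\NC(=O)c3ccco3)c3c(O)cc(OC)cc3O2)cc1` has a differently substituted core; how its core differs from that of compound 1 is not broken down here. In this assay, among the compounds with values here, compound 3 gives 2700 nM, the only numerical value among the three measured compounds.

Compound 4 `COc1ccc([C@@H]2C/C(=N\NC(=O)Cc3c[nH]c4ccccc34)c3c(O)cc(OC)cc3O2)cc1` is the not yet measured analogue of compound 3 with (1H-indol-3-yl)methyl in place of furan-2-yl on a carbonyl carbon, the same change as from compound 1 to compound 2 on the same kind of place. Because the earlier step is a step that the two limits leave unreadable from compound 1 to compound 2, the measured pair offers no readable direction for this swap. Compound 4 is therefore expected to stay close to compound 3, with the estimated step of a 1.5-fold higher number from compound 3 to compound 4 (0.17 log units; within the scatter) carrying wide uncertainty. The estimate for compound 4 in this assay is 4000 nM, between 1500 nM and 12000 nM.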

Compound 4, half-maximal inhibitory concentration: 8600 nM
Estimate against measurement, compound 4: 2.2-fold (0.33 log units) below, within the range that was stated.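

In this assay, putting (1H-indol-3-yl)methyl in place of furan-2-yl on a carbonyl carbon of the core of compound 3 gives a 3.2-fold higher number from compound 3 to compound 4 (0.50 log units; beyond the scatter), so on this core the change makes for a modestly weaker inhibitor. The same change on the core of compound 1 cannot be read, because compound 1 and compound 2 each stop at a limit of the assay and not at a number: the limit of >= 11300 nM in this assay, at which 2 of the 4 values shown sit. The series therefore holds a single readable instance of this swap, which shows what it does on one core but neither confirms nor contradicts that the change carries over to the other, and the size found on the core of compound 3 cannot be applied to the core of compound 1.

The compounds shown leave open whether the step belongs to the fused ring system of the entering group or to its methyl link, a question that a phenyl group or a 1H-indol-3-yl group joined directly to the carbonyl carbon would address. They also leave open how a carboxylic acid, an amine or a longer alkyl chain at that place would read on the core of compound 3.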